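A few compounds are considered here, and "the series" means these few. Any claim that something is new, unique, unknown or untested is made for them only; others in the source may bear on it.

Measured compounds:
compound 1 `O=C([C@@H]1C[C@H](N2CCCN(c3ccc([N+](=O)[O-])cc3)CC2)CN1)N1CCSC1` gives 2.9 nM in an assay on a cell-free system (plasma) for inhibition of Dipeptidyl peptidase 4 (Rattus norvegicus), read by fluorescence; on this read-out higher numbers stand for weaker inhibition and lower numbers for stronger inhibition
compound 2 `CN1CCN([C@@H]2CN[C@H](C(=O)N3CCSC3)C2)CC1` gives 81.1 nM in this assay

Compound 2 stands at the highest of the two numbers in this assay; its nearest neighbour, compound 1, sits at a number lower by a margin that is well beyond the usual scatter of repeated measurements. Among the measured compounds shown here, no single-point step between measured compounds is available, so the gap between compound 1 and compound 2 can only be read as what the two values show, not as a step.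

Compound 3 `COc1ccc(N2CCN([C@@H]3CN[C@H](C(=O)N4CCSC4)C3)CC2)cc1` is the next analogue and has not yet been measured in this assay. It differs from compound 2 in one place: 4-methoxyphenyl in place of methyl on an amine nitrogen in a ring. The change thus replaces a small alkyl substituent by an aromatic ring carrying a methoxy group, on the same amine nitrogen in a ring.

Because compound 1, which also carries an aromatic ring on an amine nitrogen in a ring, gives 2.9 nM, the expectation for compound 3 is a move towards lower numbers, of a size beyond the scatter, the estimated step being an 8.1-fold lower number from compound 2 to compound 3 (0.91 log units; beyond the scatter). The estimate for compound 3 in this assay is 10 nM, with a range from 3 nM to 35 nM.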

Compound 3, half-maximal inhibitory concentration: 16.9 nM
The estimate for compound 3 lay 1.7-fold (0.23 log units) below the measured number; measured number inside the range.
By their numbers in this assay, from the lowest: compound 1; then compound 3; then compound 2.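

Among the compounds shown here, with 4-methoxyphenyl in place of methyl on the amine nitrogen in the ring, this assay shows a 4.8-fold lower number from compound 2 to compound 3 (0.68 log units; beyond the scatter), the only single-place step and a modest one. This position therefore accepts an aromatic ring in place of a small alkyl group, and the change goes with stronger inhibition rather than weaker. The step brings in the aromatic ring and the methoxy group together, so their separate shares cannot be read from it, and no independent measurement bears on the reason for the shift.

The compounds shown leave open whether the aromatic ring alone accounts for the step, a question that plain phenyl on the same nitrogen would address, and whether the methoxy group can be exchanged for a nitrile, a carboxylic acid or an amine. Also open, going by these compounds, is how a longer link, such as the methylene of a benzyl group, between the nitrogen and the aromatic ring would behave, and how 4-nitrophenyl, the aromatic group of compound 1, would read on the ring of compound 3.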